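Replacing 1,3-thiazol-5-yl with cyclobutylmethyl: a cytotoxicity question

A few compounds are considered here, and "the series" means these few. Any claim that something is new, unique, unknown or untested is made for them only; others in the source may bear on it.

Results so far in an ADME assay on Huh-7 cells (Homo sapiens) for cytotoxicity, with a stated time of 72 h; a lower number here means that less compound is tolerated, a higher number that more compound is tolerated

Compound 1 `CC(C)CCn1nc(-c2cccs2)c(O)c(C2=NS(=O)(=O)c3cc(N(C(C)C)S(C)(=O)=O)ccc3N2)c1=O`: "not determined" (no result reported)
Compound 2 `CC(C)CCn1nc(-c2cccs2)c(O)c(C2=NS(=O)(=O)c3cc(S(N)(=O)=O)ccc3N2)c1=O`: > 33000 nM
Compound 3 `CC(C)CCn1nc(-c2cncs2)c(O)c(C2=NS(=O)(=O)c3cc(NS(C)(=O)=O)ccc3N2)c1=O`: > 33000 nM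

Compound 1 has no reported result, so it offers no guidance. Compound 2 reads > 33000 nM, which is a limit of the assay and not a number. Compound 3 reads > 33000 nM, which is likewise a limit and not a number. Compound 3 therefore has no exact position on the scale, and the only shared feature of the values is this one: the limit of > 33000 nM in this assay, at which 2 of the 3 values shown sit.

Compound 4 `CC(C)CCn1nc(CC2CCC2)c(O)c(C2=NS(=O)(=O)c3cc(NS(C)(=O)=O)ccc3N2)c1=O` keeps the shared core and the isopentyl group of compound 3. It carries cyclobutylmethyl in place of 1,3-thiazol-5-yl on an aromatic carbon, next to the ring nitrogen and ortho to a hydroxy group.

Going by the values given here, no two measured compounds differ in just one place, so no measured step guides this swap. The best reference is compound 3, with its limit of > 33000 nM in this assay, and so no change beyond the usual scatter is expected. The expected step is a number no higher from compound 3 to compound 4 (the limit leaves the size open) and no larger than that scatter. For compound 4 the estimated half-maximal cytotoxic concentration is 33000 nM, within an expected range from 14000 nM to 50000 nM, and a limit may well be reported again.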

Compound 4, half-maximal cytotoxic concentration: > 33000 nM
Compound 4: no number, only a limit; the forecaster's own chance of this, stated with the estimate: 80%; the middle value sits exactly at the limit.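

No step can be read from compound 3 to compound 4, because both values are limits and not numbers: the limit of > 33000 nM in this assay, at which 3 of the 4 values shown sit.

The compounds shown leave open whether cyclobutylmethyl in place of 1,3-thiazol-5-yl changes the half-maximal cytotoxic concentration in this assay at all, and if it does, in which direction and by how much.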